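Phenyl to methyl on the saturated ring carbon

The source may report more compounds than this note shows. Statements on the series, on what has been measured and on what is new or still open speak of the compounds shown alone.

In a functional assay on MDCK cells (Canis lupus familiaris) for inhibition (a lower number here means that less compound is tolerated, a higher number that more compound is tolerated), compound 1 (`COc1nc(CC2(c3ccccc3)CCCO2)cc(=O)n1C`) gives 130000 nM and compound 2 (`CCCCOc1nc(CC2(c3ccccc3)CCCO2)cc(=O)n1C`) gives 90000 nM as its value, so the two stand within the scatter of each other. Compound 3 (`COc1nc(CC2(C)CCCO2)cc(=O)n1C`) carries methyl in place of phenyl on a saturated ring carbon. Among the measured compounds shown here, the only measured step (a 1.4-fold lower number from compound 1 to compound 2 (0.16 log units; within the scatter)) lies within the scatter and sits elsewhere on the shared core, so no measured step covers this change directly. No step beyond the scatter is therefore expected, and the estimated step is small (a 1.3-fold higher number from compound 1 to compound 3 (0.12 log units; within the scatter)). For compound 3 the expected value is 170000 nM with an estimated range from 70000 nM to 400000 nM as the working span.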

Compound 3, half-maximal cytotoxic concentration: 1620000 nM
For compound 3 the middle estimate is 9.5-fold (0.98 log units) below the measured one, outside the stated range (above it).
By their numbers in this assay, from the lowest: compounds 2 and 1 (each within the scatter of the next); then compound 3.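

In this assay the saturated ring carbon next to the ring oxygen responds strongly: methyl in place of phenyl gives a 12-fold higher number from compound 1 to compound 3 (1.10 log units; beyond the scatter) as a large step, the first beyond the scatter in this series. The earlier step, a 1.4-fold lower number from compound 1 to compound 2 (0.16 log units; within the scatter) at another place on the shared core, lies within the scatter and gave no sign of this. Nothing at hand accounts for the size of the new step.

Open, as far as these compounds go, is whether the step follows the loss of the aromatic ring or the loss of carbon atoms. Cyclohexyl or ethyl on this carbon would separate the two.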